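The source may report more compounds than this note shows. Statements on the series, on what has been measured and on what is new or still open speak of the compounds shown alone.

Working notes on the series, read in a functional assay on THP-1 cells (Homo sapiens), read by MTT assay, with a stated time of 4 days (on this read-out lower numbers stand for an effect already at smaller amounts and higher numbers for an effect only at larger amounts of compound), and covering three measured compounds. Compound 1 (`CC[C@H]1OC(=O)O[C@@]1(C)[C@@H]1OC(=O)[C@H](C)[C@@H](O)[C@H](C)[C@@H](O[C@@H]2O[C@H](C)C[C@H](N(C)C)[C@H]2OC(C)=O)[C@@]2(C)C[C@@H](C)[C@H](O2)[C@@H]1C`) gives 55.7 uM here, compound 2 (`CC[C@@H](O)[C@@](C)(O)[C@@H]1OC(=O)[C@H](C)[C@@H](O[C@H]2C[C@@](C)(OC)[C@@H](O)[C@H](C)O2)[C@H](C)[C@@H](O[C@@H]2O[C@H](C)C[C@H](N(C)C)[C@H]2OC(C)=O)[C@@]2(C)C[C@@H](C)[C@H](O2)[C@@H]1C`) gives 16.1 uM and compound 3 (`CO[C@]1(C)C[C@H](O[C@H]2[C@H](C)[C@@H](O[C@@H]3O[C@H](C)C[C@H](N(C)C)[C@H]3O)[C@@]3(C)C[C@@H](C)[C@H](O3)[C@H](C)[C@H](/C(C)=N/O)OC(=O)[C@@H]2C)O[C@@H](C)[C@@H]1O`) gives 12.3 uM on the same read-out. Compound 2 thus stands within the scatter of compound 3, and the number of compound 1 lies beyond the scatter above both.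

Next is compound 4 (`CC[C@@H](O)[C@@](C)(O)[C@@H]1OC(=O)[C@H](C)[C@@H](O)[C@H](C)[C@@H](O[C@@H]2O[C@H](C)C[C@H](N(C)C)[C@H]2OC(C)=O)[C@@]2(C)C[C@@H](C)[C@H](O2)[C@@H]1C`). Its difference from compound 2 is hydrogen in place of 5-hydroxy-4-methoxy-4,6-dimethyloxan-2-yl on an oxygen on a saturated carbon and amounts to hydrogen in place of 5-hydroxy-4-methoxy-4,6-dimethyloxan-2-yl on an oxygen on a saturated carbon, leaving a hydroxy there.

Within the data shown here, no measured pair isolates this change. Among the measured compounds shown here, the only hint is that compound 1, at 55.7 uM and also without that group, has the highest number, though it differs from compound 2 elsewhere too. A moderate move to a higher number in this assay is therefore expected, with wide uncertainty. The estimated step is a 2.4-fold higher number from compound 2 to compound 4 (0.37 log units; beyond the scatter) and it is taken as real but uncertain. For compound 4 the expected value is 38 uM within an estimated range of 16 uM to 90 uM in this assay.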

Compound 4, concentration for half-maximal effect: > 100 uM
Compound 4: only a limit was reported; the forecaster's own chance of this, stated with the estimate: 10%; middle value at least 2.6-fold (0.42 log units) away from the limit.
By their numbers in this assay, from the lowest: compounds 3 and 2 (each within the scatter of the next); then compound 1. At a limit, above all of these: compound 4.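

Hydrogen in place of 5-hydroxy-4-methoxy-4,6-dimethyloxan-2-yl on an oxygen on a saturated carbon gives an at least 6.2-fold higher number from compound 2 to compound 4 (0.79 log units; beyond the scatter) in this assay, the first change at this place that can be read on its own. Compound 4 stands at a limit of the assay and not at a number, so this step has a floor and no upper size: the limit of > 100 uM in this assay, at which 1 of the 4 values shown sits.

The second step, an at least 1.7-fold higher number from compound 1 to compound 4 (0.25 log units; that floor lies within the scatter), concerns a different change on a saturated ring carbon, and its floor gives no firm separation.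

On these data alone, how far compound 4 lies past the limit remains open, as does whether the whole 5-hydroxy-4-methoxy-4,6-dimethyloxan-2-yl group is needed. As far as these compounds go, whether a methyl group or a short chain carrying an amine on that oxygen would hold the number of compound 2 also remains open.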